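The source may report more compounds than this note shows. Statements on the series, on what has been measured and on what is new or still open speak of the compounds shown alone.

Compound 1 `Cc1cc(=O)c2c(O)c(CN3CCCC3)c(O)c([C@H]3CCN(C)C[C@H]3O)c2o1`: 12%
Compound 2 `Cc1oc2c([C@H]3CCN(C)C[C@H]3O)c(O)cc(O)c2c(=O)c1C(O)c1ccccc1Br`: 21%

Both compounds were tested in a functional assay on MCF7 cells (Homo sapiens) for inhibition, read by MTT assay, with a stated time of 48 h, tested at 10 uM; a higher number here means more inhibition of growth at the concentration tested, a lower number less inhibition of growth. Compound 2, at 21%, lies within the scatter of compound 1, at 12%, so these two values cannot be ranked.

Compound 3 `Cc1oc2c([C@H]3CCN(C)C[C@H]3O)c(O)cc(O)c2c(=O)c1C(O)c1cc(F)cc(F)c1` has not yet been measured. It carries 3,5-difluorophenyl in place of 2-bromophenyl on a saturated chain carbon bound to an aromatic carbon and an oxygen on a saturated carbon.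

For the measured compounds named here, no measured pair differs in one place only, so the data do not show what such an exchange does in this assay. With nothing to indicate a direction, no change beyond the scatter is expected, and the estimate stays close to compound 2 at 21%. The estimated move is a number 3 percentage points lower from compound 2 to compound 3 (within the scatter). For compound 3 the expected value is 18%, with an estimated range from 4% to 34%.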

Compound 3, percent growth inhibition at one concentration: 25%
For compound 3 the middle estimate is 7 percentage points below the measured one; the range from low to high includes it.
By their numbers in this assay, from the lowest: compounds 1, 2 and 3 (each within the scatter of the next, the first and the last beyond it).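

In this assay, placing 3,5-difluorophenyl in place of 2-bromophenyl on a saturated chain carbon bound to an aromatic carbon and an oxygen on a saturated carbon gives a number 4 percentage points higher from compound 2 to compound 3 (within the scatter) and so does not separate the two groups. This is the first pair shown that differs in one place only, and it indicates that at this position these two halogenated phenyl groups cannot be told apart by growth inhibition at the tested concentration. The data offer no explanation for this result.

From the compounds shown here alone, whether a pyridine ring, a carboxylic acid or a longer alkyl chain on this same carbon would give a reading beyond the scatter remains open. So does the outcome of exchanging the hydroxyl on that carbon for an amine.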